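The source may hold more compounds than are shown below. What is called first, only, known or untested is meant among the compounds shown, and "the series" means these compounds.

Measured compounds:
- compound 1, `COc1ccccc1-c1cc(/C=C/c2ccc(C(=O)NO)cc2)ccn1`: 8440 nM
- compound 2, `O=C(NO)c1ccc(/C=C/c2ccnc(-c3ccc(C(F)(F)F)cc3)c2)cc1`: > 10000 nM
- compound 3, `Cc1ccc(-c2cc(/C=C/c3ccc(C(=O)NO)cc3)c(F)cn2)cc1`: > 10000 nM

The three compounds share a hydroxamic acid on a styryl-pyridine core and were tested in a functional assay on HCT-116 cells (Homo sapiens) for antiproliferative activity, read by CellTiter-Glo, with a stated time of 72 h; a higher number here means a weaker inhibitor, a lower number a stronger inhibitor. Compound 1 is the only one of the three for which a number was obtained; in this assay compound 1 gives 8440 nM. For compound 2 this assay reports only a limit, > 10000 nM, and not a number. For compound 3 the result is likewise a limit, > 10000 nM. Among the compounds with values here, two of the three results therefore sit at the limit of > 10000 nM in this assay, at which 2 of the 3 values shown sit, so no step between measured compounds can be drawn, and compound 1 stands simply as the one measurable value.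

Compound 4, `O=C(NO)c1ccc(/C=C/c2ccncc2)cc1`, is yet to be measured in this assay. It differs from compound 1 by hydrogen in place of 2-methoxyphenyl on an aromatic carbon. Within the data shown here, with no measured step available, the size of the step is uncertain. Given that the only number in hand is that of compound 1 at 8440 nM, the expected step from compound 1 to compound 4 is estimated at a 1.7-fold lower number from compound 1 to compound 4 (0.23 log units; within the scatter), within or only slightly beyond the scatter, and on balance toward a stronger inhibitor. Compound 4 is thus expected to give about 5000 nM, with a range from 1500 nM to 20000 nM.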

Compound 4, half-maximal inhibitory concentration: 3910 nM
For compound 4 the middle estimate is 1.3-fold (0.11 log units) above the measured one, and the stated range covers the measured number.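

Within the data shown here, the value of compound 4 supplies the first step that can be read in this assay, and it shows a 2.2-fold lower number from compound 1 to compound 4 (0.33 log units; beyond the scatter). This position, on an aromatic carbon next to the ring nitrogen and meta to a large group, therefore does not need the 2-methoxyphenyl for the compound to give a measurable number: with plain hydrogen there, the number is modestly lower, not lost. Steps involving compound 2 and compound 3 cannot be read, as each of these compounds gave only a limit of the assay and not a number: the limit of > 10000 nM in this assay, at which 2 of the 4 values shown sit.

Going by these compounds, what remains open is how general this single step is, since one pair says nothing about why the number moves or whether the same holds with other changes to the shared core. It is also unknown whether a small group at this place, such as an amine, a methoxy group or a short alkyl chain, would bring the number lower than hydrogen does or raise it again.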